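Cytotoxicity notes on the amide series, compound 4 outlook

The source may hold more compounds than are shown below. What is called first, only, known or untested is meant among the compounds shown, and "the series" means these compounds.

Compound 1 `COc1ccc(-c2cnc(NC(=O)c3cccc(OC)c3)n2C)cc1` has been tested in a toxicity assay on THP-1 cells (Homo sapiens) for inhibition (on this read-out higher numbers stand for lower toxicity in this test and lower numbers for higher toxicity in this test), and gives > 100000 nM, which is a limit of the assay rather than a number. Compound 2 `COc1ccc(-c2ccnc(NC(=O)c3ccc(F)cc3)c2)cc1` gives > 100000 nM, also a limit. Compound 3 `COc1ccc(-c2cnc(NC(=O)c3ccc([N+](=O)[O-])cc3)n2C)cc1` gives > 100000 nM, again a limit. Among the compounds with values here, compound 1 thus stands at the limit of > 100000 nM in this assay, at which 3 of the 3 values shown sit; no compound in the set returns a number, so no step between measured compounds can be sized. Compound 4 `COc1ccc(-c2cnc(NC(=O)CCc3ccccc3)n2C)cc1` differs from compound 1 by phenethyl in place of 3-methoxyphenyl on a carbonyl carbon. With every measured value sitting at the limit, the step of a number no higher from compound 1 to compound 4 (the limit leaves the size open) is expected to be none beyond the scatter. Compound 4 is expected to give about 100000 nM in this assay, within 40000 nM to 300000 nM, most likely reported once more only as a limit.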

Compound 4, half-maximal cytotoxic concentration: > 100000 nM
Compound 4 ended at the assay's limit; the forecaster's own chance of this, stated with the estimate: 85%; the middle value lies on the limit itself.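

Within the data shown here, compound 1 and compound 4 both sit at a limit in this assay, so no step between them can be read: the limit of > 100000 nM in this assay, at which 4 of the 4 values shown sit. The compounds shown leave open which structural change, if any, would bring a measurable cytotoxic concentration.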